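The source may hold more compounds than are shown below. What is called first, only, known or untested is meant among the compounds shown, and "the series" means these compounds.

Values in a functional assay on the whole organism with Rattus norvegicus as the target; a higher number here means that more compound is needed for the effect, a lower number that less compound is needed:

- Compound 1 `Nc1nc2ccc(C3CCCCC3)cc2s1`: > 10 mg/kg
- Compound 2 `CCCCCc1ccc2nc(N)sc2c1`: 7.5 mg/kg
- Compound 3 `CCCn1c(=N)sc2cc(OC(F)(F)F)ccc21`: 4.5 mg/kg

Compound 1 gives only a limit, > 10 mg/kg, and not a number. Compound 3 gives 4.5 mg/kg and compound 2 gives 7.5 mg/kg. These two values lie within the usual scatter of each other, so they cannot be told apart.

The next compound is compound 4 `N=c1sc2cc(OC(F)(F)F)ccc2n1Cc1ccccc1`. Compared with compound 3, it has this change: phenyl in place of ethyl on a saturated chain carbon bound to an aromatic nitrogen. Cut one bond further out, the same change reads propyl to benzyl, on a saturated chain carbon bound to an aromatic nitrogen.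

Among the measured compounds shown here, no measured pair of compounds shows a change of this kind, so the expectation in this assay is a cautious one. A modest rise is expected, meaning somewhat more compound is needed, and it may not go beyond the scatter. The estimated change is a 1.3-fold higher number from compound 3 to compound 4 (0.12 log units; within the scatter). For compound 4 the expected value is 6 mg/kg, with an estimated range from 2.5 mg/kg to 15 mg/kg.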

Compound 4, dose for half-maximal effect: > 10 mg/kg
Compound 4 ended at the assay's limit; the forecaster's own chance of this, stated with the estimate: 25%; at least 1.6-fold (0.22 log units) between middle value and limit.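

In this assay, among the compounds shown here, the change at this saturated chain carbon bound to an aromatic nitrogen gives an at least 2.2-fold higher number from compound 3 to compound 4 (0.34 log units; beyond the scatter), which is the first single-place comparison in this set and shows that this position is sensitive to replacing ethyl with phenyl. For compound 4, > 10 mg/kg is a limit and not a number. On these data alone, the true size of the step stays unknown because it ends at that limit: the limit of > 10 mg/kg in this assay, at which 2 of the 4 values shown sit.

For the compounds shown here, this is only one change at one position, so it cannot tell whether the ring itself matters or simply the larger group. A longer chain such as butyl, a shorter one such as methyl, or an amine at the end of the chain would help to show how far this position tolerates change.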